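A few compounds are considered here, and "the series" means these few. Any claim that something is new, unique, unknown or untested is made for them only; others in the source may bear on it.

Measured in a functional assay on HCT-116 cells (Homo sapiens) for antiproliferative activity, read by MTT assay, with a stated time of 48 h; a higher number here means a weaker inhibitor, a lower number a stronger inhibitor:
Compound 1 (`CCCCCCC(CCO)n1cnc2c(OC)ncnc21`): > 50000 nM as a limit.
Compound 2 (`CCCCCCC(CCO)n1cnc2c(N)ncnc21`): > 50000 nM as a limit.

Within the data shown here, compound 2 therefore stands at a limit and not at a number, and the series so far shows only the limit of > 50000 nM in this assay, at which 2 of the 2 values shown sit, with no readable potency. Compound 3 (`CCCCCCCCCC(CCO)n1cnc2c(N)ncnc21`) differs from compound 2 by propyl in place of hydrogen on a saturated chain carbon, seven bonds along the chain from an aromatic nitrogen on the same core. Among the measured compounds shown here, the only measured step is a step that the two limits leave unreadable from compound 1 to compound 2 and offers no size to carry over. In this assay only a modest shift towards stronger inhibition is therefore expected, and a further limit remains quite possible. The estimated change is an at least 1.4-fold lower number from compound 2 to compound 3 (0.15 log units; that floor lies within the scatter) and carries wide uncertainty. Compound 3 is expected near 35000 nM with an estimated range of 12000 nM to 100000 nM in this series.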

Compound 3, half-maximal inhibitory concentration: 10500 nM
Compound 3: middle estimate off by 3.3-fold (0.52 log units), on the high side, and the stated range ends above it.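

In this assay, propyl in place of hydrogen on a saturated chain carbon, seven bonds along the chain from an aromatic nitrogen, gives an at least 4.7-fold lower number from compound 2 to compound 3 (0.67 log units; beyond the scatter). Compound 2 is a limit, so this size is only a floor. This chain position carries the first change to give a number and not a limit, leaving one compound still at: the limit of > 50000 nM in this assay, at which 2 of the 3 values shown sit.

From the compounds shown here alone, whether a longer chain at this carbon moves the number further stays open. Also open, going by these compounds, is whether methoxy in place of amino on the aromatic carbon changes the number with the propyl-extended chain.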